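Hydroxy in Place of Bromo Within a Shared Core

The source may report more compounds than this note shows. Statements on the series, on what has been measured and on what is new or still open speak of the compounds shown alone.

Of the compounds shown here, three sharing one core have been measured in an ADME assay on HEL cells (Homo sapiens) for cytotoxicity; a lower number here means that less compound is tolerated, a higher number that more compound is tolerated. Compound 1, `O=C(COc1cccc2ccccc12)N/N=C/c1cccc(O)c1`, gives 100 ug/mL in this assay. Compound 2, `O=C(COc1cccc2ccccc12)N/N=C/c1cccc(Br)c1`, gives 100 ug/mL in this assay. Compound 3, `C/C(=N\NC(=O)COc1cccc2ccccc12)c1ccc(Br)cc1`, gives 20 ug/mL in this assay, the lowest of the three numbers and beyond the scatter from each of the others.

Compounds 2 and 1 differ in one place, (hydroxy in place of bromo on an aromatic carbon), and this change made the step of no change at the digits printed from compound 2 to compound 1 (within the scatter). How the core of compound 3 differs from that of compound 2 is not broken down here.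

Compound 4, `C/C(=N\NC(=O)COc1cccc2ccccc12)c1ccc(O)cc1`, has not yet been measured in this assay. It differs from compound 3 by hydroxy in place of bromo on an aromatic carbon. For the measured compounds named here, this is the same kind of change as the one from compound 2 to compound 1, though the place is not identical: in the earlier pair the group sits meta to a large group, here it sits para to a large group.

The expectation for compound 4 rests on the earlier pair, because no change at the digits printed from compound 2 to compound 1 (within the scatter) showed no movement within the scatter when bromo gave way to hydroxy. The step from compound 3 to compound 4 in this assay is therefore expected to be no change at the digits printed from compound 3 to compound 4 (within the scatter). Compound 4 is estimated to give 20 ug/mL in this assay, with a likely range from 10 ug/mL to 50 ug/mL.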

Compound 4, minimum cytotoxic concentration: 20 ug/mL
Compound 4: middle estimate and measured number agree at the digits printed; the range from low to high includes it.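

In this assay, the change from 4-bromophenyl to 4-hydroxyphenyl gave no change at the digits printed from compound 3 to compound 4 (within the scatter), so the exchange of bromo for hydroxy left the number as unmoved on this core as it had on the core of compound 1. Set beside the earlier step, the change carried over from one core to the other without a detectable difference: the same change on two cores in this assay, no change at the digits printed (within the scatter) from compound 2 to compound 1 and no change at the digits printed (within the scatter) from compound 3 to compound 4, 1.0-fold (0.00 log units) apart, within the scatter of two such steps. For the compounds shown here, this rests on only two pairs, however, and the place on the ring is not identical in them, so it does not show that the exchange would be silent on every core, nor does it say anything about why the two pairs sit at different levels, since the way their cores differ is not broken down here.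

What the compounds shown leave open is whether groups other than bromo and hydroxy would behave in the same way in that place on the ring, for example an amine, a carboxylic acid or a methoxy group. On these data alone, it also remains open whether the silent exchange would persist on a core carrying a longer chain.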